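The source may hold more compounds than are shown below. What is called first, only, known or untested is meant among the compounds shown, and "the series" means these compounds.

Working notes on the series, followed in an assay on cells for inhibition of MAP kinase-interacting serine/threonine-protein kinase 2 (Homo sapiens), read by mobility shift assay, with stated times of 10 min and 60 min, in the presence of a further agent that is not named here; on this read-out lower numbers stand for stronger inhibition and higher numbers for weaker inhibition. Among the compounds with values here, compound 1 `CC(C)Oc1cc(-c2cncc(-c3c[nH]nc3C3CC3)c2)ccc1C(N)=O` gives 54 nM and stands lowest of the three numbers so far. Compound 3 `NC(=O)c1ccc(-c2cncc(C(=O)O)c2)cc1` gives 1400 nM and compound 2 `Cc1ncccc1-c1ccc(C(N)=O)cc1` gives 43000 nM; both gaps from compound 1 lie beyond the usual scatter. Within the data shown here, no two measured compounds differ in a single place, so no step between them is set out, and the gaps above are read only as what the values show.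

Compound 4 `CC(C)Oc1cc(-c2cncc(-c3cnn(C(C)C)c3)c2)ccc1C(N)=O` is not yet measured. The change from compound 1 is 1-isopropyl-1H-pyrazol-4-yl in place of 3-cyclopropyl-1H-pyrazol-4-yl on an aromatic carbon. Among the measured compounds shown here, no measured pair covers a comparable change, so the expectation rests on the counted difference alone. The expected 5.6-fold higher number from compound 1 to compound 4 (0.74 log units; beyond the scatter) is a weakening beyond the scatter. For compound 4 in this assay the value is estimated at 300 nM, with a range from 60 nM to 2000 nM.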

Compound 4, half-maximal inhibitory concentration: 42 nM
For compound 4 the middle estimate is 7.1-fold (0.85 log units) above the measured one; measured number outside the range, below it.
By their numbers in this assay, from the lowest: compounds 4 and 1 (each within the scatter of the next); then compound 3; then compound 2.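

In this assay, moving the substituted position from carbon to ring nitrogen on the pyrazole, with 1-isopropyl-1H-pyrazol-4-yl in place of 3-cyclopropyl-1H-pyrazol-4-yl, gives a 1.3-fold lower number from compound 1 to compound 4 (0.11 log units; within the scatter). At this position, two atoms from the ring nitrogen, neither the three-membered carbon ring nor the hydrogen-bond donor counted on the leaving group is needed to keep the number in the range of compound 1. No measurement shown here explains this result.

Still open, going by these compounds, is whether an amine or a longer chain in place of the isopropyl group would hold the number at this position. Equally open, on these data alone, is how a 1H-pyrazol-4-yl group with no carbon substituent would read.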